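A Nitro Group on the Phenyl Ring of Compound 3

The source may report more compounds than this note shows. Statements on the series, on what has been measured and on what is new or still open speak of the compounds shown alone.

Of the compounds shown here, three have been measured in a functional assay on WiDr cells (Homo sapiens) for antiproliferative activity; on this read-out higher numbers stand for weaker inhibition of growth and lower numbers for stronger inhibition of growth. Compound 1 `O=[N+]([O-])c1ccc([C@H]2C[C@@H](Cl)CCO2)cc1` carries a nitrophenyl on a core unlike the other two; in this assay compound 1 reaches only the assay limit, > 100000 nM, which is not a number (the limit of > 100000 nM in this assay, at which 1 of the 3 values shown sits). Compound 2 `CC(C)C[C@H]1C[C@@H](Cl)C[C@@H](C2CCCCC2)O1` gives 26000 nM in this assay. Compound 3 `CC(C)C[C@H]1C[C@@H](Cl)C[C@@H](c2ccccc2)O1` gives 39000 nM in this assay, the highest of the two numbers, yet compound 2 lies within the scatter of it, so the two show no real separation.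

Compound 4 `CC(C)C[C@H]1C[C@@H](Cl)C[C@@H](c2ccc([N+](=O)[O-])cc2)O1` keeps the core of compound 3 and introduces one change: nitro in place of hydrogen on an aromatic carbon, para to a large group. For the measured compounds named here, no measured pair in this set traces that change on a shared core, and compound 1 carries its nitrophenyl on a different core, so it offers no step to read. The account therefore expects a step of a 1.5-fold higher number from compound 3 to compound 4 (0.19 log units; within the scatter) that could still fall within the scatter, though the limit seen for compound 1 leaves the weaker side open. In this assay compound 4 is estimated at 60000 nM, with a range from 20000 nM to 200000 nM, and a fair chance that only a limit is reported.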

Compound 4, concentration for 50% growth inhibition: 38000 nM
Estimate against measurement, compound 4: 1.6-fold (0.20 log units) above; measured number inside the range.
By their numbers in this assay, from the lowest: compounds 2, 4 and 3 (each within the scatter of the next). At a limit, above all of these: compound 1.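

On the core of compound 3, nitro in place of hydrogen on an aromatic carbon, para to a large group, gives in this assay a 1.0-fold lower number from compound 3 to compound 4 (0.01 log units; within the scatter), the first step read at this position, and the read-out does not separate the two compounds although the entering group brings 3 heavy atoms and 2 hydrogen-bond acceptors. Compound 1, which carries its nitrophenyl on a different core, stands at a limit and not at a number: the limit of > 100000 nM in this assay, at which 1 of the 4 values shown sits. Compound 4 carries a nitro group at this place on the shared core and still gives a number, so on this core the nitro group does not by itself bring a compound to that limit.

On these data alone, whether this position would read the same with an amine or a carboxylic acid in place of the nitro remains open, and so does the reading of either group on a longer chain set on the aromatic ring. One pair also leaves open whether the nitro step would read the same on any other core.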